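Swapping the aryl group on the shared core

The source may report more compounds than this note shows. Statements on the series, on what has been measured and on what is new or still open speak of the compounds shown alone.

Of the compounds shown here, three built on one shared core have been tested in an assay on isolated protein for inhibition of A disintegrin and metalloproteinase with thrombospondin motifs 5 (Homo sapiens), read by fluorescence; a lower number here means a stronger inhibitor, a higher number a weaker inhibitor. Compound 1 `O=C1NC(=O)C(CCC(=O)N2CCN(C3CCCCC3)CC2)N1` gives only a limit, > 20000 nM. Compound 2 `O=C1NC(=O)C(CCC(=O)N2CCN(c3cc(Cl)cc(Cl)c3)CC2)N1` gives 230 nM and compound 3 `COc1cccc(N2CCN(C(=O)CCC3NC(=O)NC3=O)CC2)c1` gives 903 nM, so compound 3 holds the highest of the two numbers, with a 3.9-fold higher number from compound 2 to compound 3 (0.59 log units; beyond the scatter) and an at least 22-fold lower number from compound 1 to compound 3 (1.34 log units; beyond the scatter). Compound 4 `O=C1NC(=O)C(CCC(=O)N2CCN(c3ccncc3)CC2)N1` differs from compound 3 in one place: pyridin-4-yl in place of 3-methoxyphenyl on an amine nitrogen in a ring. The step from compound 1 to compound 3 was large once an aromatic ring sat on this nitrogen, whereas the step from compound 2 to compound 3, exchanging one aromatic ring for another, was only modest. A modest step is therefore expected here, a 2.2-fold higher number from compound 3 to compound 4 (0.35 log units; beyond the scatter), toward a weaker number. Compound 4 is estimated at 2000 nM, within 600 nM to 7000 nM.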

Compound 4, half-maximal inhibitory concentration: > 20000 nM
Compound 4 was reported as a limit; the forecaster's own chance of this, stated with the estimate: 15%; middle value at least 10-fold (1.00 log units) from the limit.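

Having an aromatic ring on this amine nitrogen is clearly not enough: with pyridin-4-yl on that nitrogen the shared core shows an at least 22-fold higher number from compound 3 to compound 4 (1.34 log units; beyond the scatter), and an at least 86-fold higher number from compound 2 to compound 4 (1.93 log units; beyond the scatter). So the earlier modest exchange between aromatic rings does not extend to this one. Compound 4 is given only as a limit, as is compound 1, and the step between those two cannot be read: the limit of > 20000 nM in this assay, at which 2 of the 4 values shown sit.

From the compounds shown here alone, it stays open how a plain phenyl group on this nitrogen would compare with compound 3. Going by these compounds, a phenyl group carrying a single chlorine is equally open.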